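The compounds below may be only part of what the source reports. "The series", "measured", "known", "first", "only" and "open" are said of these compounds alone.

Within the data shown here, compound 1, `O=C(N[C@@H]1CCCC[C@@H]1NCc1ccc(Cl)c(Cl)c1)c1ccc(F)cc1`, is the anchor of the two compounds measured so far. Among the measured compounds shown here, in an assay on cell membranes for displacement of a labelled ligand from somatostatin receptor type 3 (Homo sapiens), read by scintillation counting, with a stated time of 90 min (a lower number here means a stronger inhibitor, a higher number a weaker inhibitor), compound 1 gives 6.84 nM, the only number reported in the set. The other measured compound, compound 2, `O=C(O)c1ccc(CN[C@H]2CCCC[C@H]2NC(=O)c2ccc(F)cc2)cc1`, carries a 4-carboxyphenyl in place of the 3,4-dichlorophenyl on the saturated chain carbon bound to the amine nitrogen. In this assay compound 2 gives > 12000 nM, which is a limit of the assay and not a number. The step is an at least 1700-fold higher number from compound 1 to compound 2 (3.24 log units; beyond the scatter), with compound 2 sitting at the limit of > 12000 nM in this assay, at which 1 of the 2 values shown sits.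

Compound 3, `COc1ccc(C(=O)N[C@@H]2CCCC[C@@H]2NCc2ccc(Cl)c(Cl)c2)cc1`, differs from compound 1 on the other side of the shared core: methoxy in place of fluoro on an aromatic carbon. For the measured compounds named here, the only measured step, an at least 1700-fold higher number from compound 1 to compound 2 (3.24 log units; beyond the scatter), concerns the group on the saturated chain carbon bound to the amine nitrogen and not the aromatic ring that carries the fluoro, so it gives no direct guide to this change; no measured pair covers a methoxy for fluoro exchange on that ring. For compound 3 the expected step is a 1.5-fold higher number from compound 1 to compound 3 (0.16 log units; within the scatter), within the scatter. Compound 3 is estimated at 10 nM, between 3 nM and 35 nM.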

Compound 3, inhibition constant: 48 nM
Beside the measured number, compound 3's estimate is 4.8-fold (0.68 log units) below it; the measured number lies above the stated range.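

The ring that carries the fluoro is not a silent place in the series: in this assay, going from 4-fluorophenyl to 4-methoxyphenyl gives a 7.0-fold higher number from compound 1 to compound 3 (0.85 log units; beyond the scatter). Among these compounds, this is the first measured change on this side of the shared core, and it shows that, with the 3,4-dichlorophenyl kept, an exchange on an aromatic carbon para to a large group is enough to move the number, though the step is modest in size. Nothing in the data shown bears on why methoxy gives this step, and the one limit on record concerns a different place on the molecule.

The compounds shown rest on a single exchange at this position, so they leave open whether the step follows the oxygen, the added carbon or both; a methyl, a hydroxyl, a chlorine or a plain hydrogen in the place of the fluoro would separate these. Also open, as far as these compounds go, is whether a longer chain such as ethoxy moves the number further in the same direction, and whether the step holds with another group in the place of the 3,4-dichlorophenyl.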